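The compounds below may be only part of what the source reports. "The series", "measured", "known", "first", "only" and "open" are said of these compounds alone.

Measured in an in vitro ADME assay on microsomes (Rattus norvegicus) for metabolic stability; on this read-out lower numbers stand for a shorter-lived compound and higher numbers for a longer-lived compound:

compound 1 `Cc1c2c(n3c1CCCNC[C@H](C)Nc1cc-3ccc1C(N)=O)CC(C)(C)CC2=O`: > 0.5 h, a limit and not a number
compound 2 `CC(=O)N1CCc2c(C)c3c(n2-c2ccc(C(N)=O)c(c2)N[C@@H](C)[C@H](C)C1)CC(C)(C)CC3=O`: 0.333 h
compound 3 `CC[C@H](N)C(=O)N1CCc2c(C)c3c(n2-c2ccc(C(N)=O)c(c2)N[C@@H](C)[C@H](C)C1)CC(C)(C)CC3=O`: > 0.5 h, a limit and not a number

Compound 3 has no exact half-life, only the limit of > 0.5 h. Going by the values given here, compound 1 is the one other compound reported only as a limit. The evidence on the ceiling is the limit of > 0.5 h in this assay, at which 2 of the 3 values shown sit, so the top of this small set cannot be ordered.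

Compound 4 `Cc1c2c(n3c1CCN(C(=O)C(C)(C)N)C[C@@H](C)[C@H](C)Nc1cc-3ccc1C(N)=O)CC(C)(C)CC2=O` has not yet been measured in this assay. It keeps the core of compound 3 and changes one group: 1-amino-1-methylethyl in place of 1-aminopropyl on a carbonyl carbon. In words, 1-amino-1-methylethyl stands in place of 1-aminopropyl on a carbonyl carbon, and the two compounds have the same atoms, joined differently.

Among the compounds with values here, one measured step touches this carbonyl carbon: an at least 1.5-fold higher number from compound 2 to compound 3 (0.17 log units; that floor lies within the scatter). There, 1-aminopropyl took the place of methyl. This step gives only a floor, and that floor does not clear the scatter, so it offers no reason to expect a large shift from a swap that keeps the atoms the same. The expected change is small, with no clear direction: a step that the limit leaves unreadable from compound 3 to compound 4. A report of compound 4 as a limit again would be no surprise. The estimate for compound 4 is 0.6 h, with an expected range from 0.3 h to 1.2 h.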

Compound 4, half-life: > 0.5 h
Compound 4 was reported as a limit; the forecaster's own chance of this, stated with the estimate: 65%; the middle value is on the limit's open side.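

With 1-amino-1-methylethyl in place of methyl on the carbonyl carbon, this assay shows an at least 1.5-fold higher number from compound 2 to compound 4 (0.17 log units; that floor lies within the scatter). Going by these compounds alone, compound 4 is reported as a limit, as compound 3 is, so 1-aminopropyl, with its defined stereocentre, is not the only amine-bearing group at this place that gives such a report; 1-amino-1-methylethyl, which has the same atoms joined differently, gives one too. The steps between compounds reported only as limits cannot be read, and the top of the set stays unordered: the limit of > 0.5 h in this assay, at which 3 of the 4 values shown sit.

The compounds shown leave open how far past the limit compound 3 and compound 4 lie, and so whether this swap of one group for the other changes the half-life at all. They also leave open what 1-hydroxy-1-methylethyl, with a hydroxyl in place of the amine, would give on this carbonyl carbon, a comparison that would help separate the part played by the amine from that of the branched carbon chain.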